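Trimming the selenium chain: from pentyl to methyl

A few compounds are considered here, and "the series" means these few. Any claim that something is new, unique, unknown or untested is made for them only; others in the source may bear on it.

Measured so far in one cell-based assay:
compound 1 `CSc1ccc(CNc2nc(SC)nc3ncccc23)cc1` gives 7030 nM
compound 2 `CCCCC[Se]c1nc(N)c2ccccc2n1` gives > 100000 nM
compound 3 `COc1ccc(CNc2nc([SeH])nc3ccccc23)cc1` gives > 100000 nM

The read-out is a functional assay on HT-29 cells (Homo sapiens) for cytotoxicity, read by MTT assay, with a stated time of 72 h; on this read-out lower numbers stand for stronger inhibition of growth and higher numbers for weaker inhibition of growth. For the measured compounds named here, compound 1 gives 7030 nM, the only actual number among the three. For compound 2 the result is a limit of the assay rather than a number: > 100000 nM. For compound 3 the result is likewise only a limit: > 100000 nM. So compound 2 stands at the edge of what this assay can report, where two of the three results sit (the limit of > 100000 nM in this assay, at which 2 of the 3 values shown sit).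

Compound 4 `C[Se]c1nc(N)c2ccccc2n1` has not yet been tested in this assay. It differs from compound 2 in one place: hydrogen in place of butyl on a saturated chain carbon bound to a selenium atom. Going by the values given here, no pair of measured compounds differing in a single place exists here, so there is no measured step to lean on, and the change itself is a small trimming of a chain.

The expected step is a number no higher from compound 2 to compound 4 (the limit leaves the size open), which is none beyond the usual scatter, with no clear direction. Compound 4 is estimated at 100000 nM, within a range from 20000 nM to 300000 nM, and it is expected most likely to come back as a limit again.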

Compound 4, concentration for total growth inhibition: 74800 nM
Beside the measured number, compound 4's estimate is 1.3-fold (0.13 log units) above it; the range from low to high includes it.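

In this assay compound 4 gives 74800 nM, an actual number, so a selenium compound with a methyl group at this position can produce a measurable reading. Compound 2 gives > 100000 nM, which is a limit of the assay and not a number. The change from pentyl to methyl therefore reads as an at least 1.3-fold lower number from compound 2 to compound 4 (0.12 log units; that floor lies within the scatter), and its true size stays unknown because one end of the step is only a limit: the limit of > 100000 nM in this assay, at which 2 of the 4 values shown sit.

The compounds shown leave open how the reading behaves at chain lengths between methyl and pentyl, which an ethyl or a propyl group on the selenium atom would help to settle. Also open, from the compounds shown here alone, is how much of the reading depends on the selenium atom itself, which a sulfur atom in its place on the same core would show.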